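Changing the ring size on the ether-linked bicycle

The compounds below may be only part of what the source reports. "The series", "measured", "known", "first", "only" and "open" are said of these compounds alone.

Compound 1, `C[C@@H]1NCc2ncnc(Oc3ccc4c(ccn4C(=O)Nc4cccc(C(F)(F)F)c4)c3)c21`, gives 41% in a functional assay on the whole organism (strain C57BL/6) for inhibition, with Mus musculus as the target, read by microscopy, with a stated time of 6 days, at a dose of 10 mg/kg by the oral route; on this read-out lower numbers stand for less inhibition and higher numbers for more inhibition at the one dose given (going by the name of the read-out).
Compound 2, `CC(C)c1cc(NC(=O)n2ccc3cc(Oc4ncnc5c4CCNC5)ccc32)n[nH]1`, gives 0% in this assay.
Compound 3, `CC(C)(C)c1cc(NC(=O)n2ccc3cc(Oc4ncnc5c4CCNC5)ccc32)no1`, gives 83% in this assay.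

Compound 3 stands highest of the three in this assay: compound 1 is beyond the scatter below it, and compound 2 is further still. Going by the values given here, the one measured step, a number 83 percentage points higher from compound 2 to compound 3 (beyond the scatter), concerns the group on the amide-type nitrogen, not the ether-linked bicycle. Compound 4, `C[C@@H]1NCc2ncnc(Oc3ccc4c(ccn4C(=O)Nc4cc(C(C)(C)C)on4)c3)c21`, is not yet measured. It differs from compound 3 by a group of 10 heavy atoms (7 carbon, 3 nitrogen; one five-membered non-aromatic ring with 1 hetero atom, one six-membered aromatic ring with 2 hetero atoms) in place of a group of 10 heavy atoms (7 carbon, 3 nitrogen; one six-membered non-aromatic ring with 1 hetero atom, one six-membered aromatic ring with 2 hetero atoms), on an oxygen on an aromatic ring. Among the compounds with values here, no measured step changes this part of the molecule alone, so there is no direct precedent. Compound 1 carries the same five-membered bicycle as compound 4 but a different amide substituent. In this assay compound 1 gives 41%, and its gap to compound 3 cannot be assigned to the bicycle. Compound 4 is therefore expected to stay near compound 3, with a step of a number 13 percentage points lower from compound 3 to compound 4 (beyond the scatter) that may fall within the scatter. For compound 4 the estimate is 70%, in the range 40% to 92%.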

Compound 4, a percentage reported as inhibition, in the whole organism at one dose (the size of the read-out at that dose, not a potency): 33%
Compound 4: the middle estimate sits 37 percentage points above what was measured; the whole stated range lies above it.
By their numbers in this assay, from the lowest: compound 2; then compounds 4 and 1 (each within the scatter of the next); then compound 3.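

With the 5-(tert-butyl)-1,2-oxazol-3-yl group held fixed, the change on the oxygen on an aromatic ring alone moves the result in this assay by a number 50 percentage points lower from compound 3 to compound 4 (beyond the scatter), so this place matters at one oral dose. With the five-membered non-aromatic ring in place, putting 5-(tert-butyl)-1,2-oxazol-3-yl where 3-(trifluoromethyl)phenyl stood gives a number 8 percentage points lower from compound 1 to compound 4 (within the scatter), and the high value of compound 3 therefore does not carry over to this ring. Nothing available accounts for the loss seen on this change.

The entering group differs in ring size and also has a defined stereocentre, so the compounds shown leave open which of the two goes with the loss. They also leave open how a five-membered ring carrying an ethyl group in place of the methyl group, or none at all, would read out.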